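A Methyl Where Hydrogen Sat: Following Compound 2 Onward

A few compounds are considered here, and "the series" means these few. Any claim that something is new, unique, unknown or untested is made for them only; others in the source may bear on it.

Compound 1 `Cc1cccc2c1N(CC(=O)O)C/C(=C\c1cccc(O)c1)C2=O` and compound 2 `Cc1cccc2c1N(CC(=O)O)C/C(=C\c1ccccc1)C2=O` differ in one place. In an assay on HL-60 cells for inhibition of glutathione S-transferase P (Homo sapiens), read by spectrophotometry, tested at 20 uM (on this read-out higher numbers stand for more inhibition at the one concentration tested (going by the name of the read-out) and lower numbers for less inhibition), compound 1 gives 75.6%, while in this assay compound 2 gives 27.9%. Going by the values given here, the only measured step, a number 47.7 percentage points lower from compound 1 to compound 2 (beyond the scatter), is large and concerns the loss of a hydroxy group. Among the compounds with values here, compound 2 therefore stands lowest of the two numbers known so far, with compound 1 as its only neighbour, a long way above it and well beyond the scatter.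

Compound 3 `Cc1cccc(/C=C2\CN(CC(=O)O)c3c(C)cccc3C2=O)c1` is the next compound. It differs from compound 2 by methyl in place of hydrogen on an aromatic carbon. Within the data shown here, no measured step concerns a methyl group: the one step known, a number 47.7 percentage points lower from compound 1 to compound 2 (beyond the scatter), speaks of a hydroxy group and not of a methyl, so it cannot be read across to this change. Without a step that bears on it, the step of a number 2.1 percentage points higher from compound 2 to compound 3 (within the scatter) is expected to stay within the scatter, in no particular direction. Compound 3 is accordingly estimated to give 30% in this assay, with a range from 10% to 55%.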

Compound 3, a percentage reported as inhibition, at one concentration (the size of the read-out at that concentration, not a potency): 39.1%
The estimate for compound 3 lay 9.1 percentage points below the measured number; measured number inside the range.
By their numbers in this assay, from the lowest: compound 2; then compound 3; then compound 1.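

In this assay this aromatic carbon proves responsive to more than a hydroxy group: going from phenyl to 3-methylphenyl gives a number 11.2 percentage points higher from compound 2 to compound 3 (beyond the scatter) and so shows that a plain methyl, with no hydrogen-bond donors or acceptors, also moves the number upward, though the step is only modest. Methyl nevertheless does not stand in for hydroxy at this place, as the change between the two groups gives a number 36.5 percentage points lower from compound 1 to compound 3 (beyond the scatter) and that step is large, so among hydrogen, methyl and hydroxy the order of the three compounds is set mainly by the hydroxy group of compound 1. Nothing at hand explains either step.

The compounds shown leave open how a methoxy group, an amine or a chlorine atom would read on this same aromatic carbon, and so whether hydroxy is alone in reaching the level of compound 1. They also leave open whether methyl would give a similar step on another carbon of that ring, as the methyl of compound 3 is seen only meta to a large group.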